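The source may report more compounds than this note shows. Statements on the series, on what has been measured and on what is new or still open speak of the compounds shown alone.

Measured compounds:
- compound 1 `Oc1cccc(-c2cc(-c3cccnc3)nc(-c3cccc(Cl)c3)c2)c1`: "not determined" (no result reported)
- compound 2 `Oc1ccc(-c2cc(-c3ccc(Cl)cc3)nc(-c3cccnc3)c2)cc1`: 20700 nM
- compound 3 `Oc1cccc(-c2cc(-c3ccc(Cl)cc3)nc(-c3cccnc3)c2)c1`: 16800 nM

In a functional assay on HCT-15 cells (Homo sapiens) for cytotoxicity, read by CCK-8 assay and cell counting, with a stated time of 2 days (a higher number here means a weaker inhibitor, a lower number a stronger inhibitor), compound 2 gives 20700 nM and compound 3 gives 16800 nM; compound 1 has no result. Among the compounds with values here, compound 3 thus holds the lowest of the two numbers, but its only neighbour is compound 2, and the step of a 1.2-fold lower number from compound 2 to compound 3 (0.09 log units; within the scatter) lies within the scatter, so the two are not distinguishable.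

Compound 4 `Oc1cccc(-c2cc(-c3ccc(Cl)cc3)nc(-c3ccco3)c2)c1` differs from compound 3 in one place: furan-2-yl in place of pyridin-3-yl on an aromatic carbon. Within the data shown here, no measured step touches this position or this exchange; the single step available, from compound 2 to compound 3, concerns the hydroxyphenyl group only and says nothing about the ring next to the ring nitrogen. The expectation for compound 4 in this assay therefore rests on compound 3 alone, and the step of a 1.0-fold higher number from compound 3 to compound 4 (0.01 log units; within the scatter) is estimated to stay within the scatter. Compound 4 is accordingly expected to give about 17000 nM, with a wide range from 6000 nM to 50000 nM.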

Compound 4, half-maximal inhibitory concentration: 10200 nM
Beside the measured number, compound 4's estimate is 1.7-fold (0.22 log units) above it; the range from low to high includes it.
By their numbers in this assay, from the lowest: compounds 4, 3 and 2 (each within the scatter of the next, the first and the last beyond it).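

In this assay, within the data shown here, the exchange of pyridin-3-yl for furan-2-yl next to the ring nitrogen gives the first reading of any change at this position, and the step of a 1.6-fold lower number from compound 3 to compound 4 (0.22 log units; within the scatter) leaves the two compounds indistinguishable. In this one pair, a five-membered aromatic ring with an oxygen therefore stands in for a six-membered aromatic ring with a nitrogen without a change that can be told from the scatter, so the pyridine nitrogen is not needed to keep the number in this range. Nothing available bears on why the two rings read alike.

As far as these compounds go, it remains open whether a group of another kind at this position, such as an amine or a simple methyl group, would move the number in this assay beyond the scatter. From the compounds shown here alone, it is also open whether furan-2-yl would read the same alongside the 4-hydroxyphenyl group of compound 2.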